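This account rests on a few compounds, and the source may have more. Where it says the series, first, only, none or still open, it means among the compounds named here.

Of the compounds shown here, two sharing one core have so far been tested in a functional assay on the whole organism (liver, strain NMRI) for inhibition, with Mus musculus as the target, with a stated time of 3 h, at a dose of 3 mg/kg by the oral route; a higher number here means more inhibition at the dose given (going by the name of the read-out), a lower number less inhibition. Compound 1 `CN1CCN(c2noc(-c3cc(O)c(O)c([N+](=O)[O-])c3)n2)CC1` gives 56.8%. Compound 2 `O=[N+]([O-])c1cc(-c2cc(-c3cccnc3)no2)cc(O)c1O` gives 33.6%, the lowest of the two numbers; the gap to compound 1 lies beyond the usual scatter of the measurement. Compound 3 `O=[N+]([O-])c1cc(-c2cc(-c3cnccn3)no2)cc(O)c1O` has not yet been measured. It differs from compound 2 in a single place: pyrazin-2-yl in place of pyridin-3-yl on an aromatic carbon. Among the measured compounds shown here, no measured pair in this set carries that same change, so the numbers at hand say nothing about how much it weighs. In this assay the step of a number 1.4 percentage points higher from compound 2 to compound 3 (within the scatter) is therefore expected to be small, with no clear direction, and to stay within the scatter. The estimate for compound 3 is 35%, with a range from 15% to 55%, and the measurement will show where it falls.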

Compound 3, a percentage reported as inhibition, in the whole organism at one dose (the size of the read-out at that dose, not a potency): 44.7%
For compound 3 the middle estimate is 9.7 percentage points below the measured one; low and high end bracket the measured number.
By their numbers in this assay, from the lowest: compound 2; then compound 3; then compound 1.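

Replacing pyridin-3-yl with pyrazin-2-yl on this aromatic carbon, next to the ring nitrogen of the five-membered aromatic ring, gives in this assay a number 11.1 percentage points higher from compound 2 to compound 3 (beyond the scatter). The position therefore responds to a change from a six-membered aromatic ring with 1 hetero atom to one with 2 hetero atoms, though this single pair shows only a modest step at one dose. No available evidence accounts for the difference.

Among the compounds shown here, this pair is the only instance of the change, so it remains open whether the step would carry over to another core, such as that of compound 1. Also open, going by these compounds, is how a plain phenyl ring, a pyrimidine ring or a simple amine would compare on the same aromatic carbon.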